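This account rests on a few compounds, and the source may have more. Where it says the series, first, only, none or still open, it means among the compounds named here.

Notes on the series in an ADME assay on Huh-7 cells (Homo sapiens) for cytotoxicity; a higher number here means that more compound is tolerated, a lower number that less compound is tolerated. Compound 1 `O=C(NC(=S)N1CCc2ccc(OCc3ccccc3)cc21)c1ccccc1` gives 43800 nM in this assay. Among the measured compounds shown here, compound 2 `O=C(NC(=S)N1CCc2c(OCCCCCOc3ccc(Cl)cc3)cccc21)c1ccc([N+](=O)[O-])cc1` gives 13600 nM in this assay, the lowest of the two numbers measured so far; its nearest neighbour is compound 1, whose number is higher by a margin that lies beyond the scatter. For the measured compounds named here, the two compounds differ in several places at once, so no single structural step between them can be read off, and the pair says only what the two values show.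

Compound 3 `CC(C)(C)c1ccc(C(=O)NC(=S)N2CCc3c(OCCCCCOc4ccc(Cl)cc4)cccc32)cc1` has not yet been measured in this assay. It differs from compound 2 in one place: tert-butyl in place of nitro on an aromatic carbon on an aromatic carbon of a six-membered aromatic ring of carbon only. Going by the values given here, no measured pair isolates this change, so the expectation rests on compound 2 alone. The step from compound 2 to compound 3 is expected to stay within the scatter, in either direction, a 1.1-fold lower number from compound 2 to compound 3 (0.05 log units; within the scatter). For compound 3 the estimate in this assay is 12000 nM, with a range from 4000 nM to 40000 nM.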

Compound 3, half-maximal cytotoxic concentration: > 50000 nM
Compound 3 was reported as a limit; the forecaster's own chance of this, stated with the estimate: 10%; at least 4.1-fold (0.61 log units) between middle value and limit.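

Replacing 4-nitrophenyl with 4-(tert-butyl)phenyl is the only comparison shown that changes a single place, and it shows that this position, on an aromatic carbon of a six-membered aromatic ring of carbon only and para to a large group, matters in this assay: the change gives an at least 3.6-fold higher number from compound 2 to compound 3 (0.56 log units; beyond the scatter). Compound 3 is reported only as a limit, > 50000 nM. The step is therefore bounded on one side only, and its true size cannot be read from the series: the limit of > 50000 nM in this assay, at which 1 of the 3 values shown sits.

Among the compounds shown here, the single pair does not show whether the step comes from losing nitro, from gaining tert-butyl, or from both, and it gives no sign of how other groups would rank at this position. As far as these compounds go, it is open whether an amine, a carboxylic acid or a smaller alkyl group here would give numbers nearer to that of compound 2 or to the limit of compound 3, and whether the same change would have a similar effect with a longer chain or a different ether substituent on the shared core.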